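The source may report more compounds than this note shows. Statements on the series, on what has been measured and on what is new or still open speak of the compounds shown alone.

Of the compounds shown here, three sharing one core have been tested. Compound 1 `CCc1nn(CCCN2CCN(c3ccc(C)cc3)CC2)c(=O)c(N)c1C(C)=O`, compound 2 `CCC(=O)c1c(C)nn(CCCN2CCN(c3ccc(C)cc3)CC2)c(=O)c1N` and compound 3 `C=Cc1c(CCCC)nn(CCCN2CCN(c3ccc(C)cc3)CC2)c(=O)c1N` carry different small groups on that core. In a functional assay on the whole organism (Abdomen, strain Swiss) for inhibition, with Mus musculus as the target, with stated times of 30 min, 10 min and 5 min, at a dose of 20 mg/kg by the oral route (a lower number here means a weaker effect, a higher number a stronger effect of the compound at the dose given), compound 1 gives 42%, compound 2 gives 40% and compound 3 gives 41%; the three numbers sit together, each within the usual scatter of the others, so compound 2 stands level with its two neighbours. Compound 4 `CC/C=C/c1c(C)nn(CCCN2CCN(c3ccc(C)cc3)CC2)c(=O)c1N` has not yet been measured. Its difference from compound 2 is but-1-en-1-yl in place of propanoyl on an aromatic carbon. Because compound 1 gives 42% while compound 2 gives 40% and compound 3 gives 41% despite their widely differing side groups, no step beyond the scatter is expected from compound 2 to compound 4, and the estimated change is no change at the digits printed from compound 2 to compound 4 (within the scatter). Compound 4 is thus expected to give about 40%, estimated to lie between 28% and 52%.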

Compound 4, a percentage reported as inhibition, in the whole organism at one dose (the size of the read-out at that dose, not a potency): 35%
For compound 4 the middle estimate is 5 percentage points above the measured one; the range from low to high includes it.
By their numbers in this assay, from the lowest: compounds 4, 2, 3 and 1 (each within the scatter of the next).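

In this assay, putting but-1-en-1-yl in place of propanoyl on this aromatic carbon gives a number 5 percentage points lower from compound 2 to compound 4 (within the scatter). Both groups have the same count of heavy atoms, but only propanoyl has a carbonyl oxygen, a hydrogen-bond acceptor, so at this dose the read-out does not depend on that acceptor at this position. Nothing measured here speaks to the mechanism behind this result. On these data alone, whether an amine or a carboxylic acid at this position would stay level with compound 2 remains open, as does the effect of a much longer chain.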